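Ring-nitrogen substitution on the shared core, compound 3 to compound 4

This account rests on a few compounds, and the source may have more. Where it says the series, first, only, none or still open, it means among the compounds named here.

Within the data shown here, compound 3 `COC(=O)CC(=O)N1N=C(c2ccc(-n3ccnc3)cc2)CC1c1ccc(N(C)C)cc1` gives the highest number of the three measured so far in a functional assay on HCC1806 cells (Homo sapiens) for inhibition, read by sulforhodamine B assay, tested at 10 uM (on this read-out lower numbers stand for less inhibition and higher numbers for more inhibition at the one concentration tested (going by the name of the read-out)), at 2.1%. Compound 2 `C=C(C)C(=O)N1N=C(c2ccc(-n3ccnc3)cc2)CC1c1ccc(N(C)C)cc1` gives 1.6%, and a number 0.5 percentage points higher from compound 2 to compound 3 (within the scatter). Compound 1 `CN(C)c1ccc(C2CC(c3ccc(-n4ccnc4)cc3)=NN2)cc1`, with hydrogen on the ring nitrogen, gives -20.9%; a number 23 percentage points higher from compound 1 to compound 3 (beyond the scatter) and a number 22.5 percentage points higher from compound 1 to compound 2 (beyond the scatter). Compound 4 `CN(C)c1ccc(C2CC(c3ccc(-n4ccnc4)cc3)=NN2S(C)(=O)=O)cc1` carries methylsulfonyl in place of ((methoxycarbonyl)methyl)carbonyl on an amine nitrogen in a ring. Among the measured compounds shown here, the steps above show that two different acyl groups on that nitrogen behave alike; no step involving a sulfonyl group exists here. Compound 4 is therefore expected near compound 3, with a number 0.9 percentage points higher from compound 3 to compound 4 (within the scatter) within the scatter. The estimate for compound 4 is 3%, in a range of -14% to 20%.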

Compound 4, a percentage reported as inhibition, at one concentration (the size of the read-out at that concentration, not a potency): 11.3%
The estimate for compound 4 lay 8.3 percentage points below the measured number; the measured number falls inside the stated range.
By their numbers in this assay, from the lowest: compound 1; then compounds 2, 3 and 4 (each within the scatter of the next).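

In this assay, methylsulfonyl on the amine nitrogen in the ring cannot be separated from either acyl group: a number 9.2 percentage points higher from compound 3 to compound 4 (within the scatter) and a number 9.7 percentage points higher from compound 2 to compound 4 (within the scatter). The gap to compound 1, with hydrogen on that nitrogen, therefore extends to a substituent without a carbonyl, with a number 32.2 percentage points higher from compound 1 to compound 4 (beyond the scatter). Nothing at hand bears on the reason for this. As far as these compounds go, it remains open how a longer chain ending in an amine or a carboxylic acid on this nitrogen would compare with these groups. Changes elsewhere on the shared core also remain open.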